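A Second Chloro on the Urea Phenyl Ring

A few compounds are considered here, and "the series" means these few. Any claim that something is new, unique, unknown or untested is made for them only; others in the source may bear on it.

Compound 1 `CCN(CC)CCNc1nc(-c2ccc(NC(=O)Nc3ccc(Cl)cc3)cc2)nc2ccsc12` gives 550 nM in a functional assay on MDA-MB-231 cells (Homo sapiens) for cytotoxicity, read by MTT assay, with a stated time of 72 h; a higher number here means a weaker inhibitor, a lower number a stronger inhibitor.
Compound 2 `CCN(CC)CCNc1nc(-c2ccc(NC(=O)Nc3ccccc3Cl)cc2)nc2ccsc12` gives 680 nM in this assay.

Of these two numbers, compound 2 has the higher one, yet the step of a 1.2-fold higher number from compound 1 to compound 2 (0.09 log units; within the scatter) lies within the scatter, so the two compounds cannot be told apart on these data. Compound 3 `CCN(CC)CCNc1nc(-c2ccc(NC(=O)Nc3ccc(Cl)cc3Cl)cc2)nc2ccsc12` differs from compound 2 by chloro in place of hydrogen on an aromatic carbon. Among the compounds with values here, the only measured step, a 1.2-fold higher number from compound 1 to compound 2 (0.09 log units; within the scatter), moved a single chloro group to a different place on the same ring and gave no change beyond the scatter; no measured pair adds a chloro group, so nothing in these data speaks for a large shift in either direction. The expected change a 1.1-fold lower number from compound 2 to compound 3 (0.05 log units; within the scatter) is set close to no change, with a range that allows a modest shift either way. Compound 3 is estimated at 600 nM, between 250 nM and 1500 nM.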

Compound 3, half-maximal inhibitory concentration: 2480 nM
Beside the measured number, compound 3's estimate is 4.1-fold (0.62 log units) below it, and the stated range ends below it.
By their numbers in this assay, from the lowest: compounds 1 and 2 (each within the scatter of the next); then compound 3.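

Adding a second chloro group to make the 2,4-dichlorophenyl ring of compound 3 weakens the result in this assay, seen both as a 3.6-fold higher number from compound 2 to compound 3 (0.56 log units; beyond the scatter) and as a 4.5-fold higher number from compound 1 to compound 3 (0.65 log units; beyond the scatter). A single chloro group could thus sit at either of the two places without a readable difference, yet chloro groups at both places together give a clearly weaker compound, which the move between places could not reveal. Nothing available explains this loss.

The compounds shown leave open whether the loss belongs to chlorine itself or would also follow from other pairs of groups, such as the two fluoro groups of a 2,4-difluorophenyl ring or the two methyl groups of a 2,4-dimethylphenyl ring. They also leave open how a plain phenyl ring, carrying no chloro group, would compare.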